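A few compounds are considered here, and "the series" means these few. Any claim that something is new, unique, unknown or untested is made for them only; others in the source may bear on it.

Compound 3, `C[C@@H]1CN(C(=O)OC(C)(C)C)CCN1c1ncc(OCc2ccc(C#N)cc2)cn1`, reaches 141% in an in vitro functional assay on HEK293S cells with Glucose-dependent insulinotropic receptor (Homo sapiens) as the target, read by HTRF and cAMP accumulation, with a stated time of 45 min (a lower number here means a smaller maximal response, a higher number a larger maximal response), the highest of the three numbers on hand. Compound 1, `C[C@@H]1CN(C(=O)OC(C)(C)C)CCN1c1ncc(OCC2CCN(S(C)(=O)=O)CC2)cn1`, gives 99%, and compound 2, `C[C@@H]1CN(C(=O)OC(C)(C)C)CCN1c1ncc(OCc2ccc(S(=O)(=O)N(C)C)cc2)cn1`, gives 66%, so compound 3 stands clear of both beyond the scatter.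

The new compound 4, `C[C@@H]1CN(C(=O)OC(C)(C)C)CCN1c1ncc(OCc2ccc(-n3cnnn3)cc2)cn1`, differs from compound 3 in one place: 1H-tetrazol-1-yl in place of cyano on an aromatic carbon. Two measured steps lead into compound 3 and bear on this. The step of a number 42 percentage points higher from compound 1 to compound 3 (beyond the scatter) shows how much the 4-cyanophenyl arm gains over a saturated ring on that chain carbon. Closer in kind is a number 75 percentage points higher from compound 2 to compound 3 (beyond the scatter), where a small cyano replaced a larger, acceptor-rich dimethylsulfamoyl on the same aromatic carbon and the response rose sharply. The change now runs the other way, from cyano to a larger 1H-tetrazol-1-yl carrying more acceptors, so a downward step is expected, though the two cases are not alike enough to carry the full size.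

For compound 4 the expected step is a number 51 percentage points lower from compound 3 to compound 4 (beyond the scatter), putting the estimate at 90% with a range from 55% to 125%.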

Compound 4, intrinsic activity: the largest response reached, in percent of the reference agonist's: 89%
Compound 4: middle estimate off by 1 percentage points, on the high side; measured number inside the range.
By their numbers in this assay, from the lowest: compound 2; then compounds 4 and 1 (each within the scatter of the next); then compound 3.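

In this assay, the 1H-tetrazol-1-yl group on this aromatic carbon gives up much of what cyano gave (a number 52 percentage points lower from compound 3 to compound 4 (beyond the scatter)), yet it still keeps more of the maximal response than dimethylsulfamoyl at the same place (a number 23 percentage points higher from compound 2 to compound 4 (beyond the scatter)). The aromatic arm alone therefore does not secure the high response: the step (a number 10 percentage points lower from compound 1 to compound 4 (within the scatter)) leaves the 4-(1H-tetrazol-1-yl)phenyl arm level with the saturated 1-(methylsulfonyl)piperidin-4-yl arm, so the advantage over that arm holds for 4-cyanophenyl but does not carry over to this group. Nothing on hand explains why these groups differ.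

From the compounds shown here alone, it remains open whether a smaller group such as fluoro or a primary amide on this aromatic carbon would stay near compound 3 or fall towards compound 4. The compounds shown also leave open whether a carboxylic acid there, or another five-membered ring such as 1,2,4-triazol-1-yl, would behave like the 1H-tetrazol-1-yl group.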